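From 4-Nitrophenyl to Benzamidomethyl on a Shared Core

The compounds below may be only part of what the source reports. "The series", "measured", "known", "first", "only" and "open" are said of these compounds alone.

In a functional assay on HepG2 cells (Homo sapiens) for inhibition, read by MTT assay, with a stated time of 72 h (on this read-out higher numbers stand for weaker inhibition and lower numbers for stronger inhibition), compound 1 (`O=[N+]([O-])c1ccc(-c2nnc(SCCCN3CCN(c4nc5ccccc5o4)CC3)o2)cc1`) gives 67200 nM, compound 2 (`CC(C)(C)Oc1ccc(-c2nnc(SCCCN3CCN(c4nc5ccccc5o4)CC3)o2)cc1`) gives 121000 nM and compound 3 (`O=[N+]([O-])c1ccc(-c2nnc(SCCCN3CCN(c4nc5ccccc5s4)CC3)o2)cc1`) gives 93300 nM. Compound 3 thus stands within the scatter of both other compounds and holds no distinct rank among them. Compound 4 (`O=C(NCc1nnc(SCCCN2CCN(c3nc4ccccc4s3)CC2)o1)c1ccccc1`) has benzamidomethyl in place of 4-nitrophenyl on an aromatic carbon of a five-membered aromatic ring with 2 nitrogen and 1 oxygen: benzamidomethyl in place of 4-nitrophenyl on an aromatic carbon. Among the compounds with values here, two measured steps bear on this change. Tert-butoxy in place of nitro on an aromatic carbon gave a 1.8-fold higher number from compound 1 to compound 2 (0.26 log units; within the scatter). Exchanging the 1,3-benzoxazol-2-yl group for a 1,3-benzothiazol-2-yl group gave a 1.4-fold higher number from compound 1 to compound 3 (0.14 log units; within the scatter). Neither step replaces the whole 4-nitrophenyl group, so they guide the expectation only loosely, but neither left the scatter. The expected change is a 1.1-fold lower number from compound 3 to compound 4 (0.04 log units; within the scatter), which means no step beyond the scatter in either direction. For compound 4 the estimated value is 85000 nM, with an expected range from 35000 nM to 200000 nM.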

Compound 4, half-maximal inhibitory concentration: 325000 nM
Compound 4: the middle estimate sits 3.8-fold (0.58 log units) below what was measured, outside the stated range (above it).
By their numbers in this assay, from the lowest: compounds 1, 3 and 2 (each within the scatter of the next); then compound 4.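

In this assay, replacing the entire 4-nitrophenyl group on this aromatic carbon gives a 3.5-fold higher number from compound 3 to compound 4 (0.54 log units; beyond the scatter), a modest change but the only step shown that leaves the scatter; the earlier exchanges of nitro and of 1,3-benzoxazol-2-yl did not. The read-out therefore responds to this exchange even though both groups hold one six-membered aromatic ring of carbon only and differ little in heavy atoms, the entering group bringing one hydrogen-bond donor where the leaving group has none. Nothing available explains the weaker inhibition. The compounds shown leave open whether the amide, the methylene link or the loss of the directly attached aromatic ring matters most, which a benzyl or plain phenyl group on the same carbon could help separate. They also leave open whether the same exchange would give a similar step with 1,3-benzoxazol-2-yl on the shared core.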